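Swapping the pendant hydroxyphenyl for a sulfamoylphenyl

The compounds below may be only part of what the source reports. "The series", "measured", "known", "first", "only" and "open" are said of these compounds alone.

Compound 1 `CCCS(=O)(=O)Nc1ccc(F)c(C(=O)c2n[nH]c3ncc(-c4ccccc4O)cc23)c1F` is one of three close analogues measured in an assay for binding affinity to dual specificity mitogen-activated protein kinase kinase 4 (Homo sapiens), read by KINOMEscan, tested at 100 nM; a lower number here means a stronger effect, a higher number a weaker effect of the compound at the concentration tested; in that assay compound 1 gives 9%. Compound 2 `CCCS(=O)(=O)Nc1ccc(F)c(C(=O)c2n[nH]c3ncc(-c4ccc(O)cc4)cc23)c1F` gives 0.75%, and compound 3 `CCCS(=O)(=O)Nc1ccc(F)c(C(=O)c2n[nH]c3ncc(-c4ccc([N+](=O)[O-])cc4)cc23)c1F` gives 4.2%. Compound 1 holds the highest of the three numbers, yet both steps away from it stay within the scatter: a number 8.3 percentage points lower from compound 1 to compound 2 (within the scatter) and a number 4.8 percentage points lower from compound 1 to compound 3 (within the scatter). The step between the other two, a number 3.5 percentage points higher from compound 2 to compound 3 (within the scatter), is likewise small.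

Compound 4 `CCCS(=O)(=O)Nc1ccc(F)c(C(=O)c2n[nH]c3ncc(-c4ccc(S(N)(=O)=O)cc4)cc23)c1F` has not been measured. Its change from compound 1 is 4-sulfamoylphenyl in place of 2-hydroxyphenyl on an aromatic carbon. Within the data shown here, two measured steps bear on this: both start from compound 1 and both replace the 2-hydroxyphenyl with a phenyl carrying a different group, a 4-hydroxyphenyl in a number 8.3 percentage points lower from compound 1 to compound 2 (within the scatter) and a 4-nitrophenyl in a number 4.8 percentage points lower from compound 1 to compound 3 (within the scatter). Neither moved the read-out beyond the scatter, although both ran lower, so for compound 4 no shift beyond the scatter is expected in this assay, with any drift most likely downward. The expected step is a number 5 percentage points lower from compound 1 to compound 4 (within the scatter). Compound 4 is therefore estimated to give about 4% in this assay, with a likely range from 0.5% to 15%.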

Compound 4, a percentage reported as activity, at one concentration (the size of the read-out at that concentration, not a potency): 0.25%
The estimate for compound 4 lay 3.8 percentage points above the measured number, and the stated range ends above it.
By their numbers in this assay, from the lowest: compounds 4, 2, 3 and 1 (each within the scatter of the next).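

At this position the core of compound 1 also accepts a 4-sulfamoylphenyl, a larger group than the 2-hydroxyphenyl it replaces and one that brings in sulfur and nitrogen, with a number 8.8 percentage points lower from compound 1 to compound 4 (within the scatter) in this assay and no shift beyond the scatter. On the same phenyl ring, sulfamoyl in place of nitro gives a number 4 percentage points lower from compound 3 to compound 4 (within the scatter) and sulfamoyl in place of hydroxy gives a number 0.5 percentage points lower from compound 2 to compound 4 (within the scatter) as its step, so this read-out does not separate the three groups at the 4-position of the phenyl from one another. Nothing available here explains why such different groups read alike.

It remains open whether an amine, a carboxylic acid or a longer chain on this phenyl ring, or an unsubstituted phenyl, would also stay within the scatter of these compounds, or whether one of them would finally move the number beyond it. Also open is whether differences among these four compounds would appear at a lower concentration or in a full potency measurement, which a single-concentration read-out cannot show.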